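Carboxy in place of fluoro: notes on the series

The compounds below may be only part of what the source reports. "The series", "measured", "known", "first", "only" and "open" are said of these compounds alone.

In a functional assay on MDA-MB-231 cells (Homo sapiens) for cytotoxicity, read by MTT assay, with a stated time of 24 h (on this read-out lower numbers stand for stronger inhibition and higher numbers for weaker inhibition), compound 1 (`Fc1ccc(-c2nc3cccnc3n2C2CCCC2)cc1`) gives 500 nM, the second highest of three numbers. Compound 3 (`Fc1cccc(-c2nc3cccnc3n2C2CCCCC2)c1`) gives 342 nM, within the scatter of compound 1. Compound 2 (`Fc1cc(F)cc(C2Nc3cccnc3N2C2CCCC2)c1`) gives 2100 nM, a higher number than that of compound 1 and beyond the scatter.

Compound 4 (`O=C(O)c1ccc(-c2nc3cccnc3n2C2CCCC2)cc1`) carries carboxy in place of fluoro on an aromatic carbon, para to a large group (carboxy in place of fluoro on an aromatic carbon). Going by the values given here, no measured pair shows this change, so the expectation rests on the structural change alone. In this assay the expected step (a 3.0-fold higher number from compound 1 to compound 4 (0.48 log units; beyond the scatter)) is towards weaker inhibition, beyond the scatter. Compound 4 is estimated at 1500 nM, with an expected range of 350 nM to 7000 nM.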

Compound 4, half-maximal inhibitory concentration: 600 nM
Estimate against measurement, compound 4: 2.5-fold (0.40 log units) above; low and high end bracket the measured number.
By their numbers in this assay, from the lowest: compounds 3, 1 and 4 (each within the scatter of the next); then compound 2.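

At the position para to a large group on the aromatic carbon, carboxy in place of fluoro gives a 1.2-fold higher number from compound 1 to compound 4 (0.08 log units; within the scatter) in this assay. Going by these compounds alone, this is the first reading for this change, and it shows that the position takes carboxy, with 3 heavy atoms, 1 hydrogen-bond donor and 1 hydrogen-bond acceptor against the 1 heavy atom and no donor of fluoro, with no step beyond the scatter. No measurement at hand accounts for this result.

On these data alone, whether an amine or a methyl ester at this place reads the same remains open. So does whether carboxy behaves alike on the core of compound 3.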